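Inverting Two Ring Stereocentres in a Peroxide Acid

This account rests on a few compounds, and the source may have more. Where it says the series, first, only, none or still open, it means among the compounds named here.

Measured compounds:
compound 1 `C=C1CCCC(C)(C)C1CC[C@]1(C)CC[C@@H]([C@@H](C)C(=O)O)OO1`: > 10000 nM
compound 2 `C=C1CCC[C@H]2[C@](C)(CC[C@]3(C)CC[C@@H]([C@@H](C)C(=O)O)OO3)[C@@H](C)CC[C@]12C`: 600 nM

Of the compounds shown here, two have been measured in a functional assay on CAKI-1 cells (Homo sapiens) for inhibition; on this read-out higher numbers stand for weaker inhibition of growth and lower numbers for stronger inhibition of growth. Compound 1 `C=C1CCCC(C)(C)C1CC[C@]1(C)CC[C@@H]([C@@H](C)C(=O)O)OO1` gives only a limit of this assay, > 10000 nM; the reading is a limit, not a number (the limit of > 10000 nM in this assay, at which 1 of the 2 values shown sits). Compound 2 `C=C1CCC[C@H]2[C@](C)(CC[C@]3(C)CC[C@@H]([C@@H](C)C(=O)O)OO3)[C@@H](C)CC[C@]12C` gives 600 nM in this assay. Going by the values given here, no step between two measured compounds that differ in a single place is available, so compound 1 stands only as a limit, and compound 2 is the sole compound for which a number is known.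

Compound 3 `C=C1CCCC(C)(C)C1CC[C@@]1(C)CC[C@H]([C@@H](C)C(=O)O)OO1` differs from compound 1 in this way: the two compounds have the same atoms and bonds; at least one stereo element is drawn with a configuration in one of them and without one in the other: 2 of 4 stereo elements differ; a stereocentre at a saturated ring carbon is drawn R in compound 1 and S in compound 3; a stereocentre at a saturated ring carbon is drawn S in compound 1 and R in compound 3. The two compounds have the same atoms and bonds; two of four stereo elements differ, each at a saturated ring carbon. Nothing measured here tells how such an inversion alone moves this read-out. The step is expected to be none beyond the scatter: a number no higher from compound 1 to compound 3 (the limit leaves the size open). Compound 3 is therefore estimated at 10000 nM, in the range 2500 nM to 30000 nM, with a fair chance that this assay again reports only a limit.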

Compound 3, concentration for 50% growth inhibition: 2000 nM
Estimate against measurement, compound 3: 5.0-fold (0.70 log units) above; the measured number lies below the stated range.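

Going by these compounds alone, compound 3 supplies the first step between compounds that differ in one place, and it shows that this read-out responds to configuration alone: with atoms and bonds unchanged, inverting the two saturated ring carbons gives an at least 5.0-fold lower number from compound 1 to compound 3 (0.69 log units; beyond the scatter) in this assay. Compound 1 gives a limit and not a number, so this step has a lower bound on its size but no upper end: the limit of > 10000 nM in this assay, at which 1 of the 3 values shown sits. The reading of the step as a pure change of configuration also depends on how the two structures are drawn, and it carries this caveat: the fact that one of compounds 1 and 3 is drawn with a defined configuration and the other without, at the place where they differ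

The compounds shown leave open whether one of the two inverted ring carbons carries the step or both are needed, and whether the same inversion would move the number in the same direction on the larger core of compound 2. They also leave open whether the configuration of compound 3 would keep its growth inhibition if the carboxylic acid gave way to a methyl ester or a primary amide.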